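Swapping the Nitrogen Substituent of Compound 2 for Benzyl

The source may report more compounds than this note shows. Statements on the series, on what has been measured and on what is new or still open speak of the compounds shown alone.

Compound 2 `Cc1nc(-c2ccc3c(c2)c(C#N)cn3CCNS(C)(=O)=O)sc1C(=O)O` stands lowest of the two compounds measured in a functional assay on the whole organism (strain Sprague-Dawley) for inhibition, with Rattus norvegicus as the target, with a stated time of 1 h, at a dose of 10 mg/kg by the oral route (a higher number here means more inhibition at the dose given (going by the name of the read-out), a lower number less inhibition), where compound 2 gives 0%. Its nearest neighbour, compound 1 `COCC(C)n1cc(C#N)c2cc(-c3nc(C)c(C(=O)O)s3)ccc21`, gives 14.1% in this assay. Among the compounds with values here, the one measured step, a number 14.1 percentage points lower from compound 1 to compound 2 (beyond the scatter), shows that the group on the aromatic nitrogen moves the read-out by a modest amount. Compound 3 `Cc1nc(-c2ccc3c(c2)c(C#N)cn3Cc2ccccc2)sc1C(=O)O` differs from compound 2 by phenyl in place of (methanesulfonamido)methyl on a saturated chain carbon bound to an aromatic nitrogen. Within the data shown here, this change sits on the same nitrogen substituent as the measured step, but neither measured compound carries phenyl there, so no direct precedent exists. Among the measured compounds shown here, with the only comparable step being modest, the writer expects a step of a number 8 percentage points higher from compound 2 to compound 3 (within the scatter), a small rise at most and possibly none beyond the scatter. Compound 3 is therefore estimated at 8%, with a range from 0% to 25%.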

Compound 3, a percentage reported as inhibition, in the whole organism at one dose (the size of the read-out at that dose, not a potency): 10%
Beside the measured number, compound 3's estimate is 2 percentage points below it, within the range that was stated.
By their numbers in this assay, from the lowest: compounds 2, 3 and 1 (each within the scatter of the next, the first and the last beyond it).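

Of the three groups on this aromatic nitrogen, only benzyl carries an aromatic ring, and in this assay the change from 2-(methanesulfonamido)ethyl gives a number 10 percentage points higher from compound 2 to compound 3 (within the scatter) and so does not separate the two groups. Set against 1-(methoxymethyl)ethyl, benzyl gives a number 4.1 percentage points lower from compound 1 to compound 3 (within the scatter) and again no separation, so compound 3 cannot be told apart from either neighbour, even though compound 1 and compound 2 stand apart beyond the scatter. Nothing measured here gives a reason for these readings.

The compounds shown leave open whether an aromatic ring on this saturated chain carbon matters at all. Whether a pyridylmethyl, a phenethyl or a fluorobenzyl group would lift the read-out clear of the scatter also remains unanswered.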